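Shortening the chain and replacing the terminal group of compound 3

The source may hold more compounds than are shown below. What is called first, only, known or untested is meant among the compounds shown, and "the series" means these compounds.

Among the compounds with values here, in a functional assay on the whole organism (stomach) with Rattus norvegicus as the target (on this read-out lower numbers stand for an effect already at smaller amounts and higher numbers for an effect only at larger amounts of compound), compound 3, with the structure `C/N=C(/NC#N)NCCCCCn1nc(-c2ccccc2)ccc1=O`, gives 100 mg/kg, the highest of the three numbers measured so far. Compound 2 (`CC/N=C(/NC#N)NCCCCn1nc(-c2ccccc2)ccc1=O`) gives 92 mg/kg, and the two differ only by a step that is a 1.1-fold higher number from compound 2 to compound 3 (0.04 log units; within the scatter). Compound 1 (`C/N=C(\S)NCCCCCn1nc(-c2ccccc2)ccc1=O`) gives 35.3 mg/kg, the lowest of the three. The step from compound 1 to compound 3 is a 2.8-fold higher number from compound 1 to compound 3 (0.45 log units; beyond the scatter), and the step from compound 1 to compound 2 is a 2.6-fold higher number from compound 1 to compound 2 (0.42 log units; beyond the scatter).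

Compound 4, with the structure `N/C(S)=N/CCCCn1nc(-c2ccccc2)ccc1=O`, has not yet been measured in this assay. Relative to compound 3, the change is a group of 4 heavy atoms (1 carbon, 2 nitrogen, 1 sulfur; no ring) in place of a group of 8 heavy atoms (4 carbon, 4 nitrogen; no ring), on a saturated chain carbon, four bonds along the chain from an aromatic nitrogen. This move runs back toward the kind of group found in compound 1, which gave the lowest number of the set, so a lower number is expected for compound 4. The step from compound 1 to compound 3 suggests how large this reversal might be. The estimated step is a 2.5-fold lower number from compound 3 to compound 4 (0.40 log units; beyond the scatter), and compound 4 is expected to give about 40 mg/kg, with a range from 20 mg/kg to 85 mg/kg.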

Compound 4, dose for half-maximal effect: 36.3 mg/kg
Compound 4: middle estimate off by 1.1-fold (0.04 log units), on the high side; low and high end bracket the measured number.
By their numbers in this assay, from the lowest: compounds 1 and 4 (each within the scatter of the next); then compounds 2 and 3 (each within the scatter of the next).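

In this assay the sulfur-bearing group of 4 heavy atoms, on a saturated chain carbon, four bonds along the chain from an aromatic nitrogen, gives a 2.8-fold lower number from compound 3 to compound 4 (0.44 log units; beyond the scatter) and also a 2.5-fold lower number from compound 2 to compound 4 (0.40 log units; beyond the scatter) against the two groups of 8 heavy atoms. Set against the sulfur-bearing group of compound 1, it shows a 1.0-fold higher number from compound 1 to compound 4 (0.01 log units; within the scatter), so the two sulfur-bearing compounds stand level and both lie apart from the two nitrile-bearing compounds, with no exception among these four. Nothing measured here explains this separation.

The compounds shown do not tell whether the separation follows the sulfur atom itself or the whole group that carries it. From the compounds shown here alone, what an amine or a carboxylic acid would give at this place, or how a longer chain would read, also remains open.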